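The source may hold more compounds than are shown below. What is called first, only, known or untested is meant among the compounds shown, and "the series" means these compounds.

Working notes on the series. Compound 1 `CC(C)CNC(=C\C(=O)/C=C/c1ccc(O)cc1)/C=C/c1ccc(O)cc1` carries an isobutylamino group on the shared core. Among the measured compounds shown here, in a functional assay on EA.hy 926 cells (Homo sapiens), read by fluorescence, tested at 10 uM (on this read-out lower numbers stand for a weaker effect and higher numbers for a stronger effect at the one concentration tested), compound 1 gives 119%, the highest of the two numbers measured so far. Compound 2 `CCC(C)NC(=C\C(=O)/C=C/c1ccc(OC(C)=O)c(OC)c1)/C=C/c1ccc(OC(C)=O)c(OC)c1` is the nearest comparator; in this assay compound 2 gives 105%, a number lower than that of compound 1 by more than the usual scatter. Compound 2 differs from compound 1 in more than one place, so the gap cannot be tied to any single change.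

Compound 3 `O=C(/C=C(/C=C/c1ccc(O)cc1)NC1CCCCC1)/C=C/c1ccc(O)cc1` is not yet measured. Against compound 1 the change is cyclohexyl in place of isobutyl on an amine nitrogen: the group on the amine nitrogen is exchanged for one with a six-membered non-aromatic ring of carbon only, with no donors, no acceptors and no charge either way. With no measured step of this kind in the series, the expectation is a step of no size beyond the scatter, a number 7 percentage points lower from compound 1 to compound 3 (within the scatter). Compound 3 is therefore estimated to give 112%, within a range of 95% to 130%.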

Compound 3, a percentage reported as activity, at one concentration (the size of the read-out at that concentration, not a potency): 299%
Estimate against measurement, compound 3: 187 percentage points below; measured number above the stated range.
By their numbers in this assay, from the lowest: compound 2; then compound 1; then compound 3.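

In this assay, among the compounds shown here, the group on the amine nitrogen is not a neutral place: with the rest of compound 1 unchanged, cyclohexyl in place of isobutyl gives a number 180 percentage points higher from compound 1 to compound 3 (beyond the scatter) and is the first step that can be tied to one change. Both groups are carbon only, with no donors, no acceptors and no charge, so a change of this plain kind is enough to move the number far beyond the scatter. Nothing at hand bears on what lies behind this step.

As far as these compounds go, whether the step follows the ring itself or the larger carbon group remains open; an open hexyl chain or a cyclopentyl on the same nitrogen would separate the two. Also open, from the compounds shown here alone, is how a phenyl or a piperidinyl group at this nitrogen would read.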